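The source may report more compounds than this note shows. Statements on the series, on what has been measured and on what is new or still open speak of the compounds shown alone.

Of the compounds shown here, three sharing one core have been measured in a functional assay on NCI/ADR cells (Homo sapiens) for cytotoxicity, read by sulforhodamine B assay (on this read-out lower numbers stand for stronger inhibition of growth and higher numbers for weaker inhibition of growth), so far.

Compound 1 `CC1=CC[C@@H]([C@@](C)(O)CCCC(C)(C)NC(=S)N/N=C\c2ccccc2)CC1` gives 23800 nM
Compound 2 `CC1=CC[C@@H]([C@@](C)(O)CCCC(C)(C)NC(=S)N/N=C\c2ccc(C)cc2)CC1` gives 30500 nM
Compound 3 `CC1=CC[C@@H]([C@@](C)(O)CCCC(C)(C)NC(=S)N/N=C\c2cccc([N+](=O)[O-])c2)CC1` gives 38000 nM

On these numbers, compound 3 cannot be told apart from the other two. Its nearest neighbour is compound 2 and its furthest is compound 1, yet both gaps lie within the ordinary spread of repeat measurements.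

The next compound is compound 4 `CC1=CC[C@@H]([C@@](C)(O)CCCC(C)(C)NC(=S)N/N=C\c2ccc([N+](=O)[O-])cc2)CC1` and its difference from compound 3 is 4-nitrophenyl in place of 3-nitrophenyl on a carbon with a double bond to nitrogen in other words 4-nitrophenyl in place of 3-nitrophenyl on a carbon with a double bond to nitrogen. The two have the same atoms, joined differently.

For the measured compounds named here, no measured step shows this exact change, so the evidence is indirect. Nitro in place of hydrogen gave a 1.6-fold higher number from compound 1 to compound 3 (0.20 log units; within the scatter) and methyl in place of hydrogen gave a 1.3-fold higher number from compound 1 to compound 2 (0.11 log units; within the scatter) while the swap of 4-methylphenyl for 3-nitrophenyl gave a 1.2-fold higher number from compound 2 to compound 3 (0.10 log units; within the scatter) and so none of these three changes moved the number beyond the scatter. A similarly small step is expected here. In this assay the expected step is a 1.2-fold lower number from compound 3 to compound 4 (0.07 log units; within the scatter) and no move beyond the scatter is expected in either direction.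

Compound 4 is estimated at 32000 nM with 18000 nM to 55000 nM as the expected range.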

Compound 4, concentration for total growth inhibition: > 100000 nM
Compound 4: only a limit was reported; the forecaster's own chance of this, stated with the estimate: 5%; at least 3.1-fold (0.49 log units) between middle value and limit.
By their numbers in this assay, from the lowest: compounds 1, 2 and 3 (each within the scatter of the next). At a limit, above all of these: compound 4.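

In this assay, for the compounds shown here, compound 4 gives > 100000 nM, which is a limit of the assay and not a number, and it is the only such result here: the limit of > 100000 nM in this assay, at which 1 of the 4 values shown sits. Moving the nitro group, with no atom gained or lost, gives an at least 2.6-fold higher number from compound 3 to compound 4 (0.42 log units; beyond the scatter), so this is the first change to reach beyond the scatter, and it shows that the read-out depends on how the nitro group is joined to the ring and not only on its presence. Going by these compounds alone, the same 4-nitrophenyl group also separates compound 4 from the 4-methylphenyl of compound 2, with an at least 3.2-fold higher number from compound 2 to compound 4 (0.51 log units; beyond the scatter), and from the unsubstituted phenyl of compound 1, with an at least 4.2-fold higher number from compound 1 to compound 4 (0.62 log units; beyond the scatter), whereas the earlier steps among compounds 1, 2 and 3 all stayed within the scatter.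

As far as these compounds go, all three new steps are lower bounds, so the true size of the change remains open. From the compounds shown here alone, it is also open whether an amine or a methoxy group in the place of the nitro group on the 4-substituted ring would follow the 4-nitrophenyl of compound 4 or the 4-methylphenyl of compound 2.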